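Trading an acetate for an acetoxybenzoate on one core

A few compounds are considered here, and "the series" means these few. Any claim that something is new, unique, unknown or untested is made for them only; others in the source may bear on it.

Of the compounds shown here, three built on a shared core have so far been measured in an ADME assay on WI-38 cells (Homo sapiens) for inhibition, read by MTT assay, with a stated time of 72 h; on this read-out lower numbers stand for stronger inhibition and higher numbers for weaker inhibition. Compound 1 `O=C(OC1(C(=O)Nc2ccc([N+](=O)[O-])cc2)CCCCC1)c1ccc(Br)cc1` gives 523 nM, compound 2 `O=C(/C=C/c1ccccc1)OC1(C(=O)Nc2ccc([N+](=O)[O-])cc2)CCCCC1` gives 41 nM, and compound 3 `CC(=O)OC1(C(=O)Nc2ccc([N+](=O)[O-])cc2)CCCCC1` gives 386 nM. Compound 3 therefore holds the second highest of the three numbers: the step of a 1.4-fold lower number from compound 1 to compound 3 (0.13 log units; within the scatter) stays within the scatter, whereas the step of a 9.4-fold higher number from compound 2 to compound 3 (0.97 log units; beyond the scatter) lies beyond it, as does the step of a 13-fold lower number from compound 1 to compound 2 (1.11 log units; beyond the scatter).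

Compound 4 `CC(=O)Oc1ccccc1C(=O)OC1(C(=O)Nc2ccc([N+](=O)[O-])cc2)CCCCC1` has not yet been measured. It differs from compound 3 in one place: 2-acetoxyphenyl in place of methyl on a carbonyl carbon. The measured step that speaks most directly to this change is a 1.4-fold lower number from compound 1 to compound 3 (0.13 log units; within the scatter), in which a methyl also stands against a substituted phenyl on a carbonyl carbon, and that step stayed within the scatter. The step of a 9.4-fold higher number from compound 2 to compound 3 (0.97 log units; beyond the scatter) shows that a larger group on this carbonyl carbon can lower the number strongly, but there the group was a 2-phenylethenyl rather than a substituted phenyl.

On this basis the number expected for compound 4 in this assay is 300 nM, with a range from 80 nM to 1200 nM. The expected step is thus a 1.3-fold lower number from compound 3 to compound 4 (0.11 log units; within the scatter), small and probably within the scatter.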

Compound 4, half-maximal inhibitory concentration: 48.4 nM
The estimate for compound 4 lay 6.2-fold (0.79 log units) above the measured number; measured number below the stated range.
By their numbers in this assay, from the lowest: compounds 2 and 4 (each within the scatter of the next); then compounds 3 and 1 (each within the scatter of the next).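

In this assay, putting 2-acetoxyphenyl in place of methyl gives an 8.0-fold lower number from compound 3 to compound 4 (0.90 log units; beyond the scatter) and so shows that a substituted phenyl on this carbonyl carbon can shift the number well beyond the scatter, which the 4-bromophenyl of compound 1 had not done relative to methyl. Replacing 4-bromophenyl with 2-acetoxyphenyl gives an 11-fold lower number from compound 1 to compound 4 (1.03 log units; beyond the scatter) as well, so having a phenyl ring at this position does not by itself set the number, and compound 1 goes against any simple rule that a group larger than methyl brings the number down. The change from 2-phenylethenyl to 2-acetoxyphenyl gives a 1.2-fold higher number from compound 2 to compound 4 (0.07 log units; within the scatter) and stays within the scatter, which shows that two quite different groups on this carbonyl carbon can give matching results.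

The compounds shown leave open whether the acetoxy part of 2-acetoxyphenyl is needed, a question that an unsubstituted phenyl or a 2-hydroxyphenyl group in its stead could address. No supporting measurement is available to explain the differences among these groups.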